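The compounds below may be only part of what the source reports. "The series", "measured", "known", "first", "only" and "open" are said of these compounds alone.

Measured compounds in an ADME assay on MRC5 cells (Homo sapiens) for cytotoxicity, read by resazurin assay, with a stated time of 72 h; a lower number here means a stronger inhibitor, a higher number a weaker inhibitor:
Compound 1, `CC1(COc2ccc(-c3ccc(F)nc3F)nc2)CCn2cc([N+](=O)[O-])nc2O1`. In this assay compound 1 gives > 64000 nM, a limit of the assay and not a number.
Compound 2, `CC1(COc2cccc(-c3ccc(F)cc3F)n2)CCn2cc([N+](=O)[O-])nc2O1`. Compound 2 gives > 64000 nM, again only a limit.
Compound 3, `CC1(COc2ccc(-c3ccc(F)cc3F)nc2)CCn2cc([N+](=O)[O-])nc2O1`. Compound 3 gives > 64000 nM, also a limit.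

Going by the values given here, every value so far sits at the limit of > 64000 nM in this assay, at which 3 of the 3 values shown sit. The change from compound 3 to compound 1 is 2,6-difluoropyridin-3-yl in place of 2,4-difluorophenyl on an aromatic carbon. Its step, a step that the two limits leave unreadable from compound 3 to compound 1, is left unreadable by the limit of > 64000 nM in this assay, at which 3 of the 3 values shown sit, so nothing is known of its size. Compound 2 and compound 3 share the same atoms joined differently; the difference between the two cores is not broken down here.

The unmeasured compound 4, `CC1(COc2cccc(-c3ccc(F)nc3F)n2)CCn2cc([N+](=O)[O-])nc2O1`, differs from compound 2 by 2,6-difluoropyridin-3-yl in place of 2,4-difluorophenyl on an aromatic carbon. This is the same kind of change as that from compound 3 to compound 1, not the same: in compound 4 the place is meta to a large group, in compound 1 para to a large group. For compound 4 the expected step is a step that the limit leaves unreadable from compound 2 to compound 4. This expectation rests on compound 2 standing at > 64000 nM. It also rests on compound 1 remaining at > 64000 nM after the same kind of change. Compound 4 is therefore estimated at 100000 nM, most likely reported again as a limit, with a range of 40000 nM to 300000 nM.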

Compound 4, half-maximal inhibitory concentration: > 64000 nM
Compound 4: only a limit was reported; the forecaster's own chance of this, stated with the estimate: 85%; the middle value is on the limit's open side.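

In this assay compound 4 gives > 64000 nM, a limit of the assay and not a number. No step can be read between compound 2 and compound 4, nor any new one among compounds 1 to 4: the limit of > 64000 nM in this assay, at which 4 of the 4 values shown sit.

Still open, on these data alone, is whether 2,6-difluoropyridin-3-yl in place of 2,4-difluorophenyl, or the difference between the cores, changes this read-out at all.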